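From Pyridin-2-yl to 4-Cyanophenyl on the Aromatic Nitrogen

The source may hold more compounds than are shown below. What is called first, only, known or untested is meant among the compounds shown, and "the series" means these compounds.

Measured compounds:
compound 1 `C[C@H](Nc1ncnc2[nH]cnc12)c1nn(-c2ccccn2)c2cc(F)ccc12`: 22%
compound 2 `C[C@H](Nc1ncnc2[nH]cnc12)c1nn(-c2cccnc2)c2cc(Cl)ccc12`: 13%

Of the compounds shown here, two have been tested in a functional assay on HepG2 cells (Homo sapiens) for inhibition, read by sulforhodamine B assay, with a stated time of 72 h, tested at 10 uM; a higher number here means more inhibition at the concentration tested (going by the name of the read-out), a lower number less inhibition. In this assay compound 1 gives 22% and compound 2 gives 13%. The two numbers lie within the scatter of each other, so compound 1 is highest of the two only on the face of the figures, not beyond the noise. Compound 3 `C[C@H](Nc1ncnc2[nH]cnc12)c1nn(-c2ccc(C#N)cc2)c2cc(F)ccc12` carries the change (4-cyanophenyl in place of pyridin-2-yl on an aromatic nitrogen). Within the data shown here, no measured pair shows this change, so there is no step to lean on. Compound 3 is expected to give 20%, within 5% to 40%. The step of a number 2 percentage points lower from compound 1 to compound 3 (within the scatter) is expected to stay within the scatter.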

Compound 3, a percentage reported as inhibition, at one concentration (the size of the read-out at that concentration, not a potency): 57%
Beside the measured number, compound 3's estimate is 37 percentage points below it; the whole stated range lies below it.
By their numbers in this assay, from the lowest: compounds 2 and 1 (each within the scatter of the next); then compound 3.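

In this assay, the group on the aromatic nitrogen now proves able to move the read-out: 4-cyanophenyl in place of pyridin-2-yl gives a number 35 percentage points higher from compound 1 to compound 3 (beyond the scatter), the only step shown and one that rests on a single pair. Nothing measured here explains this step.

On these data alone, it remains open whether the nitrile or the carbon-only ring carries the step, which a plain phenyl or a 4-carboxyphenyl on this nitrogen could help separate. As far as these compounds go, whether the same change would hold on the core of compound 2 also remains open.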